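Methyl in place of methylamino: compound 3 to compound 4

This account rests on a few compounds, and the source may have more. Where it says the series, first, only, none or still open, it means among the compounds named here.

Going by the values given here, the three measured members share one core and one sugar and differ at a single position of the core and in the pendant group. Compound 3 `CNc1ncnc2c1c(-c1ccsc1)cn2[C@@H]1O[C@H](CO)[C@@H](O)[C@H]1O` carries a methylamino at that position. In a functional assay on K562 cells (Homo sapiens), read by MTT assay, with a stated time of 72 h (a lower number here means a stronger inhibitor, a higher number a weaker inhibitor), compound 3 reaches only the limit, > 20000 nM. Compound 1 `CN(C)c1ncnc2c1c(-c1ccsc1)cn2[C@@H]1O[C@H](CO)[C@@H](O)[C@H]1O` carries a dimethylamino at the same position. In this assay compound 1 likewise gives only the limit, > 20000 nM. The step that the two limits leave unreadable from compound 1 to compound 3 is thus unreadable. Among the compounds with values here, compound 2 `Cc1ncnc2c1c(-c1cc3ccccc3o1)cn2[C@@H]1O[C@H](CO)[C@@H](O)[C@H]1O` carries a methyl but differs from compound 4 in the pendant group, so no step between them is counted. In this assay compound 2 gives only the limit, > 20000 nM. Within the data shown here, every value so far sits at the limit of > 20000 nM in this assay, at which 3 of the 3 values shown sit.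

Compound 4 `Cc1ncnc2c1c(-c1ccsc1)cn2[C@@H]1O[C@H](CO)[C@@H](O)[C@H]1O` arises from compound 3 by methyl in place of methylamino on an aromatic carbon. Among the measured compounds shown here, the only measured step at this position, a step that the two limits leave unreadable from compound 1 to compound 3, has no readable size, and compound 2 with the same methyl also stands at the limit. No shift beyond the scatter can be predicted in this assay, and a limit is the likeliest outcome. Compound 4 is therefore estimated at 30000 nM, with a range of 12000 nM to 100000 nM. The expected step is a step that the limit leaves unreadable from compound 3 to compound 4, effectively none.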

Compound 4, half-maximal inhibitory concentration: 5550 nM
The estimate for compound 4 lay 5.4-fold (0.73 log units) above the measured number; measured number outside the range, below it.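

With methyl on this aromatic carbon of the shared core, the series gives its first number rather than a limit in this assay, and the other compounds all remain at that limit: the limit of > 20000 nM in this assay, at which 3 of the 4 values shown sit.

Replacing methylamino with methyl gives an at least 3.6-fold lower number from compound 3 to compound 4 (0.55 log units; beyond the scatter), and replacing dimethylamino with methyl gives an at least 3.6-fold lower number from compound 1 to compound 4 (0.55 log units; beyond the scatter); both sizes are floors, so the full effect of removing either amine at this position cannot be read. Methyl alone does not suffice, since the pendant group also counts: thiophen-3-yl in place of 1-benzofuran-2-yl gives an at least 3.6-fold lower number from compound 2 to compound 4 (0.55 log units; beyond the scatter), and among the compounds shown only methyl together with thiophen-3-yl leaves the limit.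

Going by these compounds, how an unsubstituted amino group, a chlorine atom or an ethyl chain at this position would stand against methyl remains open, and with it whether the gain belongs to methyl itself or to the absence of an amine nitrogen. Also open, on these data alone, is how far the pendant group can vary with methyl kept in place, for example with a phenyl or furan-2-yl ring.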